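This account rests on a few compounds, and the source may have more. Where it says the series, first, only, none or still open, it means among the compounds named here.

Three compounds that share one core differ only in the aryl group hung on that core and in the length of the chain that carries the sulfamoylamino end. In a functional assay on HT-29 cells (Homo sapiens) for antiproliferative activity, read by sulforhodamine B assay, with a stated time of 48 h (on this read-out higher numbers stand for weaker inhibition of growth and lower numbers for stronger inhibition of growth), compound 2 (`NS(=O)(=O)NCC1CCN(c2cc(-c3cccc4ccccc34)ncn2)CC1`) gives 6800 nM, the lowest of the two numbers seen so far. Compound 3 (`NS(=O)(=O)NCCC1CCN(c2cc(-c3ccccc3F)ncn2)CC1`) gives 51800 nM in this assay, a higher number and beyond the usual scatter of this assay, so compound 2 is the stronger inhibitor of growth of the two. Compound 1 (`COc1ccccc1-c1cc(N2CCC(CNS(N)(=O)=O)CC2)ncn1`) reports only a limit of the assay, > 100000 nM, and not a number.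

Compound 4 (`NS(=O)(=O)NCCC1CCN(c2cc(-c3cccc4ccccc34)ncn2)CC1`) keeps the aryl group of compound 2 and changes only the chain: (sulfamoylamino)methyl in place of sulfamoylamino on a saturated chain carbon bound to a saturated ring carbon. Among the compounds with values here, no pair of measured compounds differs by this change alone, so there is no measured step to lean on. Since the sulfamoylamino end stays the same and the chain grows by a single carbon, the expectation is a step from compound 2 to compound 4 that stays within the scatter, or at most slightly beyond it in either direction. Compound 4 is therefore expected to give 8000 nM in this assay, with a likely range from 3000 nM to 25000 nM. That estimate means a step of a 1.2-fold higher number from compound 2 to compound 4 (0.07 log units; within the scatter) that is expected to be small.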

Compound 4, concentration for 50% growth inhibition: 3500 nM
Compound 4: the middle estimate sits 2.3-fold (0.36 log units) above what was measured; low and high end bracket the measured number.
By their numbers in this assay, from the lowest: compounds 4 and 2 (each within the scatter of the next); then compound 3. At a limit, above all of these: compound 1.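

Within the data shown here, this is the first step in the set that changes one place alone, so the chain can now be judged with the aryl group held fixed. Replacing (sulfamoylamino)methyl with 2-(sulfamoylamino)ethyl, on the saturated ring carbon of the shared core, gives a 1.9-fold lower number from compound 2 to compound 4 (0.29 log units; within the scatter) in this assay. For this aryl group, then, the two chain lengths cannot be told apart in this read-out, and the sulfamoylamino end is tolerated at either distance from the core without a change that repeat measurements could separate from noise.

Going by these compounds, what remains open is whether a longer chain, such as 3-(sulfamoylamino)propyl, or an amine or a carboxylic acid in place of the sulfamoylamino end, would move the number beyond the scatter, and whether the chain behaves the same way with other aryl groups. Compound 1 cannot help with that question, since it reports a limit of the assay and not a number: the limit of > 100000 nM in this assay, at which 1 of the 4 values shown sits.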